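The source may hold more compounds than are shown below. What is called first, only, known or untested is meant among the compounds shown, and "the series" means these compounds.

Of the compounds shown here, three with a shared core have been measured in an assay on isolated protein for inhibition of protein kinase C theta type (Homo sapiens), read by TR-FRET, with a stated time of 2 h; a higher number here means a weaker inhibitor, a lower number a stronger inhibitor. Compound 1 `N#Cc1cnc(NCc2cnccc2C(F)(F)F)cc1NC[C@H]1C[C@@H](O)C1` gives 300 nM. Compound 2 `N#Cc1cnc(NCc2ccccc2C(F)(F)F)cc1N[C@H]1C[C@H](C(N)=O)C1` gives 5000 nM. Compound 3 `N#Cc1cnc(NCc2cncnc2C(F)(F)F)cc1N[C@H]1CC[C@@H](O)CC1` gives 450 nM. Among these, compound 1 has the smallest number, but compound 3 lies within the usual scatter of compound 1, so the two cannot be told apart, while compound 2 lies clearly beyond that scatter.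

The next compound, compound 4 `CC1(C)C[C@H](Nc2cc(NCc3cnccc3C(F)(F)F)ncc2C#N)CC[C@@H]1O`, has not yet been measured in this assay. It differs from compound 1 in one place: 4-hydroxy-3,3-dimethylcyclohexyl in place of (3-hydroxycyclobutyl)methyl on a nitrogen on an aromatic ring. The (3-hydroxycyclobutyl)methyl group, with its four-membered non-aromatic ring, gives way to the 4-hydroxy-3,3-dimethylcyclohexyl group, with its six-membered non-aromatic ring, on a nitrogen on an aromatic ring, keeping one hydrogen-bond donor and one hydrogen-bond acceptor.

Within the data shown here, no step between two measured compounds matches this change, so the expectation rests on the three values themselves. Compound 3, whose structure also holds a six-membered non-aromatic ring at that nitrogen, gives a number within the scatter of compound 1, so the expected step is a 1.2-fold higher number from compound 1 to compound 4 (0.07 log units; within the scatter), small and in no clear direction beyond the scatter. Compound 4 is therefore estimated at 350 nM, with a likely range from 100 nM to 1200 nM.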

Compound 4, half-maximal inhibitory concentration: 7 nM
The estimate for compound 4 lay 50-fold (1.70 log units) above the measured number; the measured number lies below the stated range.
By their numbers in this assay, from the lowest: compound 4; then compounds 1 and 3 (each within the scatter of the next); then compound 2.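

In this assay, among these compounds, the group on a nitrogen on an aromatic ring turns out to have a strong hold on the number: 4-hydroxy-3,3-dimethylcyclohexyl in place of (3-hydroxycyclobutyl)methyl gives a 43-fold lower number from compound 1 to compound 4 (1.63 log units; beyond the scatter), the first reading from a pair of compounds that differ in this one place only. The step comes with the same count of hydrogen-bond donors and acceptors on both sides, while the ring goes from four-membered to six-membered and the group from 6 heavy atoms to 9 heavy atoms. No measurement in hand explains why this swap gives so large a step.

Several features change together in this one swap, so the pair cannot say how much of the step belongs to the larger ring, the two methyl groups on it, or the loss of the methyl link to the nitrogen. A 4-hydroxycyclohexyl group without those two methyl groups on the core of compound 4 would separate these features, and a 3,3-dimethylcyclohexyl group without the hydroxyl, or with an amine in its place, would test what the hydroxyl contributes.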